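Thiophene for Pyridine at the Alkyne Terminus

This account rests on a few compounds, and the source may have more. Where it says the series, first, only, none or still open, it means among the compounds named here.

Measured so far:
- Compound 1, `OCCCCC#Cc1ccccc1C#Cc1ccccc1`: 150 nM
- Compound 2, `OCCCCC#Cc1ccccc1C#Cc1ccccn1`: 21800 nM

Going by the values given here, in a functional assay on SF-295 cells (Homo sapiens) for cytotoxicity (a lower number here means a stronger inhibitor of growth, a higher number a weaker inhibitor of growth), compound 2 gives the highest of the two numbers known; its nearest neighbour is compound 1, which gives 150 nM. Among the compounds with values here, the only measured step, a 150-fold higher number from compound 1 to compound 2 (2.16 log units; beyond the scatter), shows that exchanging phenyl for pyridin-2-yl on the triple-bonded carbon weakens growth inhibition strongly.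

Compound 3, `OCCCCC#Cc1ccccc1C#Cc1cccs1`, has not been measured. It differs from compound 2 by thiophen-2-yl in place of pyridin-2-yl on a triple-bonded carbon. Within the data shown here, no measured pair carries exactly this exchange, but the step from compound 1 to compound 2 suggests that the six-membered ring with one nitrogen is unfavourable here, and a five-membered ring with one sulfur is a different case. Compound 3 is therefore expected to recover part of that loss, giving a step of a 24-fold lower number from compound 2 to compound 3 (1.38 log units; beyond the scatter) in this assay. The estimate for compound 3 is 900 nM, within 150 nM to 8000 nM.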

Compound 3, concentration for 50% growth inhibition: 19000 nM
Beside the measured number, compound 3's estimate is 21-fold (1.32 log units) below it, outside the stated range (above it).
By their numbers in this assay, from the lowest: compound 1; then compounds 3 and 2 (each within the scatter of the next).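

In this assay, the change shows a 1.1-fold lower number from compound 2 to compound 3 (0.06 log units; within the scatter), so the loss seen with pyridin-2-yl is not confined to that six-membered ring: thiophen-2-yl, a five-membered ring with sulfur as its hetero atom, does not restore growth inhibition. Going by these compounds alone, the exchange of phenyl for thiophen-2-yl gives a 130-fold higher number from compound 1 to compound 3 (2.10 log units; beyond the scatter), leaving phenyl as the only one of the three rings on this triple-bonded carbon that goes with a strong inhibitor of growth. Nothing available explains why these two rings differ from phenyl in this way.

The compounds shown leave open whether a ring without a hetero atom is what matters, which a cyclohexyl group could test, or whether a phenyl ring carrying a methoxy group would hold the number of compound 1. They also do not say how an amine in place of the hydroxyl would act.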